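Moving the hydroxyl on one aryl arm of a shared core

The source may hold more compounds than are shown below. What is called first, only, known or untested is meant among the compounds shown, and "the series" means these compounds.

Three compounds were measured in an assay on isolated protein for inhibition of DNA topoisomerase 1 (Homo sapiens), with a stated time of 30 min, tested at 20 uM; a higher number here means a stronger effect of the compound at the concentration tested, a lower number a weaker effect. Compound 1 `Oc1ccc(-c2cc(-c3cccs3)cc(-c3ccccc3O)n2)cc1` gives 2%, compound 2 `Oc1ccc(-c2cc(-c3ccco3)cc(-c3ccc(O)cc3)n2)cc1` gives 0%, and compound 3 `Oc1ccc(-c2cc(-c3ccoc3)cc(-c3ccccc3O)n2)cc1` gives 3.9%. Compound 3 holds the highest of the three numbers, yet its gaps to compound 1 and to compound 2 both lie within the scatter, so none of the three can be called more active than another. Within the data shown here, the only single-point step among them, a number 1.9 percentage points higher from compound 1 to compound 3 (within the scatter), is also within the scatter.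

Compound 4 `Oc1ccc(-c2cc(-c3ccoc3)cc(-c3ccc(O)cc3)n2)cc1` is not yet measured. It differs from compound 3 as follows: 4-hydroxyphenyl in place of 2-hydroxyphenyl on an aromatic carbon. Among the measured compounds shown here, no measured step changes a 2-hydroxyphenyl into a 4-hydroxyphenyl by itself; the step from compound 1 to compound 3 concerns the five-membered ring instead and stayed within the scatter. For the measured compounds named here, compound 2, carrying two 4-hydroxyphenyl groups, shows 0%, while compound 1 shows 2%, but that pair also differs in the five-membered ring, so it shows only that both numbers are small. Compound 4 is therefore expected to move only by a number 1.9 percentage points lower from compound 3 to compound 4 (within the scatter), a step not expected to exceed the scatter. The estimate for compound 4 in this assay is 2%, with a range from 0% to 8%.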

Compound 4, a percentage reported as inhibition, at one concentration (the size of the read-out at that concentration, not a potency): 0%
Beside the measured number, compound 4's estimate is 2 percentage points above it, within the range that was stated.
By their numbers in this assay, from the lowest: compounds 2, 4, 1 and 3 (each within the scatter of the next).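

Among these compounds, compound 4 gives the first direct reading of this change on the shared core: 4-hydroxyphenyl in place of 2-hydroxyphenyl, on the aromatic carbon next to the ring nitrogen, gives a number 3.9 percentage points lower from compound 3 to compound 4 (within the scatter) in this assay and so does not separate the two hydroxyphenyl groups at this position. It also adds a reading for the five-membered ring, since furan-3-yl in place of furan-2-yl gives no change at the digits printed from compound 2 to compound 4 (within the scatter) and so does not separate these two furan groups either. Nothing available explains these numbers.

Going by these compounds, with all four numbers this small, it remains open whether any change at this position can produce a step beyond the scatter. An amine or a carboxylic acid in place of the hydroxyl on this arm would be one way to test that.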